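Fluoro for Trifluoromethyl on a Shared Core

This account rests on a few compounds, and the source may have more. Where it says the series, first, only, none or still open, it means among the compounds named here.

Three compounds have been tested in an ADME assay on J774.A1 cells (Mus musculus) for cytotoxicity, with a stated time of 48 h; a lower number here means that less compound is tolerated, a higher number that more compound is tolerated:

Compound 1, `O=[N+]([O-])c1ccc(OC2C(Cn3ccnc3)CCCC2Cn2ccnc2)c(C(F)(F)F)c1`, gives 14.4 ug/mL.
Compound 2, `O=[N+]([O-])c1ccc(OC2C(Cn3ccnc3)CCCC2Cn2ccnc2)c(F)c1`, gives 39.4 ug/mL.
Compound 3, `O=[N+]([O-])c1ccc(O[C@H]2CCCC[C@@H]2Cn2ccnc2)c(C(F)(F)F)c1`, gives 13.8 ug/mL.

Compound 1 and compound 2 share a core and differ in one place, (fluoro in place of trifluoromethyl on an aromatic carbon). In this assay the change gave a 2.7-fold higher number from compound 1 to compound 2 (0.44 log units; beyond the scatter). Compound 3 carries a different core; the difference between the two cores is not broken down here. In this assay compound 3 and compound 1 give numbers that lie within the scatter of each other.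

Compound 4, `O=[N+]([O-])c1ccc(O[C@H]2CCCC[C@@H]2Cn2ccnc2)c(F)c1`, has not yet been measured. It differs from compound 3 in one place, (fluoro in place of trifluoromethyl on an aromatic carbon), the same change that separates compound 2 from compound 1. Within the data shown here, the expectation for compound 4 rests on that single earlier pair, because the shift a 2.7-fold higher number from compound 1 to compound 2 (0.44 log units; beyond the scatter) is the only measured instance of this change. On that basis a step of similar size is estimated, a 2.7-fold higher number from compound 3 to compound 4 (0.43 log units; beyond the scatter). For compound 4 in this assay the estimated value is 37 ug/mL, with a range from 20 ug/mL to 70 ug/mL.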

Compound 4, half-maximal cytotoxic concentration: > 100 ug/mL
Compound 4 gave a limit, no number (the forecaster's own chance of this, stated with the estimate: 5%); at least 2.7-fold (0.43 log units) between middle value and limit.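

On the second core, fluoro in place of trifluoromethyl on the aromatic carbon again moved the number in the same direction in this assay, giving an at least 7.2-fold higher number from compound 3 to compound 4 (0.86 log units; beyond the scatter). Compound 4 gives > 100 ug/mL, which is a limit of the assay and not a number. The direction of the change therefore carries across both cores in this pair of pairs, but the data do not show that its size carries across, and two cores are too few to support a rule for the wider series: the same change on two cores in this assay, a 2.7-fold higher number (0.44 log units; beyond the scatter) from compound 1 to compound 2 and an at least 7.2-fold higher number (0.86 log units; beyond the scatter) from compound 3 to compound 4; the limit leaves it open whether they differ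

The compounds shown leave open how groups such as chloro, methyl or methoxy would behave on this aromatic carbon, as only trifluoromethyl and fluoro appear there. They also leave open whether the step would keep its direction if an amine or a nitrile stood in place of the nitro group.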